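The source may hold more compounds than are shown below. What is called first, only, known or untested is meant among the compounds shown, and "the series" means these compounds.

Measured so far:

compound 1, `C=CCOc1cc(OC)c(C(=O)/C=C/Cc2ccccc2)c(OCC=C)c1` — 14800 nM
compound 2, `COCc1cc(O)c(C(=O)/C=C/c2cc(OC)c(OC)c(OC)c2)c(OC)c1` — 133000 nM

Both compounds were tested in a toxicity assay on cells (Macrophage, Mus musculus, strain BALB/c) for cytotoxicity, read by MTT assay; on this read-out higher numbers stand for weaker inhibition and lower numbers for stronger inhibition. Compound 1 gives 14800 nM, the lower of the two numbers, and compound 2 gives 133000 nM, a higher number whose gap to compound 1 lies beyond the usual scatter of repeated measurements. Going by the values given here, no pair of compounds differing in a single place has been measured, so no measured step is at hand to guide a forecast.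

The compound still to be measured is compound 3, `C=CCOc1cc(OC)c(C(=O)/C=C/c2cccc(OC)c2)c(OCC=C)c1`. It is built on the core of compound 1, with one difference: 3-methoxyphenyl in place of benzyl on a double-bonded chain carbon bound to a double-bonded chain carbon. Only the group on that double-bonded chain carbon changes; the rest of the molecule stays as it is in compound 1.

Among the compounds with values here, with no measured step of this kind available, the size of the change is uncertain. In this assay the step expected is a 1.5-fold lower number from compound 1 to compound 3 (0.17 log units; within the scatter), a modest one toward a lower number that may not go beyond the scatter. Compound 3 is expected to give 10000 nM, with a range from 3000 nM to 35000 nM.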

Compound 3, half-maximal inhibitory concentration: 13100 nM
Compound 3: middle estimate off by 1.3-fold (0.12 log units), on the low side, within the range that was stated.
By their numbers in this assay, from the lowest: compounds 3 and 1 (each within the scatter of the next); then compound 2.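

In this assay, going by these compounds alone, the only single-place step available gives a 1.1-fold lower number from compound 1 to compound 3 (0.05 log units; within the scatter), so the numbers for these two compounds cannot be told apart. Within the data shown here, this is the first direct look at this position: 3-methoxyphenyl can take the place of benzyl on a double-bonded chain carbon bound to a double-bonded chain carbon, bringing in an oxygen and a hydrogen-bond acceptor, with no change beyond the scatter on this read-out. No measured information is available to explain why the two compounds match.

This single step cannot show whether the position would tolerate very different groups, such as an amine, a carboxylic acid or a longer chain, or whether it is simply insensitive to any replacement in this cell read-out. Compound 2 differs from compound 1 and compound 3 in more than one place, so its higher number in this assay cannot be assigned to any one group, and it remains open which part of the molecule accounts for that gap.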